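The source may report more compounds than this note shows. Statements on the series, on what has been measured and on what is new or still open speak of the compounds shown alone.

Measured so far:
compound 1 `O=C(N1CCC(c2nc(-c3ccc4ccccc4n3)no2)CC1)N1CCCc2ccccc21` gives 2300 nM
compound 2 `Cn1c(-c2noc(C3CCN(C(=O)NC4CCCCC4)CC3)n2)nc2ccccc21` gives 89 nM
compound 3 `COc1ccccc1NC(=O)N1CCC(c2noc(-c3ccc4ccccc4n3)n2)CC1` gives 2400 nM

All three were read in a functional assay on Shh Light II cells (Mus musculus) for inhibition, read by a luciferase reporter (on this read-out higher numbers stand for weaker inhibition and lower numbers for stronger inhibition), where compound 1 lies within the scatter of compound 3, while compound 2 has a lower number, beyond the scatter. Compound 4 `COc1ccccc1N(C)C(=O)N1CCC(c2nc(-c3ccc4ccccc4n3)no2)CC1`, not yet measured, carries (2-methoxyphenyl)(methyl)amino in place of 1,2,3,4-tetrahydroquinolin-1-yl on a carbonyl carbon on the core of compound 1. For the measured compounds named here, no measured pair shows this change directly. Compound 3, which also holds a 2-methoxyphenyl group, gives 2400 nM in this assay, so no step beyond the scatter is expected. The expected 1.3-fold lower number from compound 1 to compound 4 (0.11 log units; within the scatter) is therefore small. Compound 4 is estimated at 1800 nM with a range from 500 nM to 6000 nM in this measurement.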

Compound 4, half-maximal inhibitory concentration: 3100 nM
Compound 4: the middle estimate sits 1.7-fold (0.24 log units) below what was measured, and the stated range covers the measured number.
By their numbers in this assay, from the lowest: compound 2; then compounds 1, 3 and 4 (each within the scatter of the next).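

In this assay, putting (2-methoxyphenyl)(methyl)amino in place of 1,2,3,4-tetrahydroquinolin-1-yl on the carbonyl carbon gives a 1.3-fold higher number from compound 1 to compound 4 (0.13 log units; within the scatter) and so stays within the scatter. This position therefore tolerates the loss of the non-aromatic ring and the added hydrogen-bond acceptor without a readable shift on the core of compound 1. No evidence bears on this result.
The compounds shown leave open whether a dimethylamino or morpholin-4-yl group on the carbonyl carbon would hold the number as well. They also leave open whether a carboxylic acid on the aromatic ring would move it beyond the scatter.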